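This account rests on a few compounds, and the source may have more. Where it says the series, first, only, none or still open, it means among the compounds named here.

Compound 1 `CCCCCCCCCCCCNC(=O)[C@@H](NC(=O)c1ccccc1)[C@@H](C)O`: in a functional assay on HepG2 cells (Homo sapiens) for cytotoxicity, read by MTT assay, with a stated time of 48 h (on this read-out lower numbers stand for stronger inhibition and higher numbers for weaker inhibition), compound 1 reaches only the limit > 400000 nM.
Compound 2 `CCCCCCCCCCCCCCNC(=O)[C@@H](NC(=O)c1ccccc1)[C@@H](C)O`: in this assay compound 2 gives 54200 nM.

Going by the values given here, compound 2 holds the only number obtained in this assay. Among the compounds with values here, the one other value is a limit, at which compound 1 sits (the limit of > 400000 nM in this assay, at which 1 of the 2 values shown sits). The step of an at least 7.3-fold lower number from compound 1 to compound 2 (0.86 log units; beyond the scatter) concerns only the saturated chain. Compound 3 `CCCCCCCCCCCCCCNC(=O)[C@@H](NC(=O)c1cc2ccccc2n1C)[C@@H](C)O` differs from compound 2 by 1-methyl-1H-indol-2-yl in place of phenyl on a carbonyl carbon. Within the data shown here, no measured step touches the group on the carbonyl carbon, so no guide exists for this change. The estimate for compound 3 is therefore 40000 nM, with a range of 10000 nM to 160000 nM. The step of a 1.4-fold lower number from compound 2 to compound 3 (0.13 log units; within the scatter) is expected to stay within the scatter, though the range is wide.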

Compound 3, half-maximal inhibitory concentration: 34500 nM
Compound 3: middle estimate off by 1.2-fold (0.06 log units), on the high side; measured number inside the range.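

Going by these compounds alone, the first step at the carbonyl carbon is a 1.6-fold lower number from compound 2 to compound 3 (0.20 log units; within the scatter) in this assay, so this position accepts 1-methyl-1H-indol-2-yl in place of phenyl with the number staying inside the usual scatter. The entering group adds a five-membered aromatic ring and a nitrogen, and neither addition moves the read-out beyond that scatter. Nothing at hand offers a reason for this result. Still open, as far as these compounds go, is whether a carboxylic acid or an amine on this group, or a longer saturated chain, would shift the number beyond the scatter.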